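The source may hold more compounds than are shown below. What is called first, only, known or untested is meant among the compounds shown, and "the series" means these compounds.

Measured compounds:
Compound 1 `CCCCCCCCO[C@@H]1O[C@@H](C)[C@H](OC(=O)CCCCC)[C@@H](O[C@@H]2O[C@@H](C)[C@H](OC(C)=O)[C@@H](O[C@@H]3O[C@@H](C)[C@H](OC(C)=O)[C@@H](OC(C)=O)[C@H]3O)[C@H]2OC(C)=O)[C@H]1O` gives 4.9 ug/mL in a functional assay on Col2 cells (Homo sapiens) for cytotoxicity; on this read-out lower numbers stand for an effect already at smaller amounts and higher numbers for an effect only at larger amounts of compound.
Compound 2 `CCCCCCCCO[C@@H]1O[C@@H](C)[C@H](OC(=O)CCCCC)[C@@H](O[C@@H]2O[C@@H](C)[C@H](OC(C)=O)[C@@H](O)[C@H]2OC(C)=O)[C@H]1O` gives only a limit in this assay, namely > 20 ug/mL.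
Compound 3 `CCCCCCCCO[C@@H]1O[C@@H](C)[C@H](OC(=O)CCCCC)[C@@H](O[C@@H]2O[C@@H](C)[C@H](OC(C)=O)[C@@H](OC(C)=O)[C@H]2OC(C)=O)[C@H]1O` gives 9 ug/mL in this assay.

Of the two numbers recorded, compound 3 has the higher one, yet its gap to compound 1 lies within the scatter, so the two are not told apart. Compound 4 `CCCCCCCCO[C@@H]1O[C@@H](C)[C@H](OC(=O)CCCCC)[C@@H](O[C@@H]2O[C@@H](C)[C@H](O)[C@@H](OC(C)=O)[C@H]2OC(C)=O)[C@H]1O` differs from compound 3 by hydrogen in place of acetyl on an oxygen on a saturated carbon. Within the data shown here, the one measured step, an at least 2.2-fold lower number from compound 2 to compound 3 (0.34 log units; beyond the scatter), ran the other way: adding an acetyl on an oxygen on a saturated carbon lowered the number. Taking an acetyl away in compound 4, though at a different oxygen, is therefore expected to raise the number, by a 1.7-fold higher number from compound 3 to compound 4 (0.22 log units; within the scatter). Compound 4 is expected near 15 ug/mL, between 7 ug/mL and 30 ug/mL, and a limit such as the limit of > 20 ug/mL in this assay, at which 1 of the 3 values shown sits, is possible.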

Compound 4, concentration for half-maximal effect: > 20 ug/mL
Compound 4: no number, only a limit (the forecaster's own chance of this, stated with the estimate: 40%); middle value at least 1.3-fold (0.12 log units) from the limit.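

In this assay the change from acetoxy to hydroxy on this oxygen gives an at least 2.2-fold higher number from compound 3 to compound 4 (0.34 log units; beyond the scatter) and so shows that the acetyl here counts too, which the earlier step, made at a different oxygen, could not show. Compound 4 carries a limit, so the step is a lower bound only, and that limit recurs in the set: the limit of > 20 ug/mL in this assay, at which 2 of the 4 values shown sit.

As far as these compounds go, how far the number rises on losing this acetyl stays open. Also open, from the compounds shown here alone, is whether a methyl ether or a butyryl ester on this oxygen would serve as the acetyl does.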